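A Group Exchange on Compound 3

The source may hold more compounds than are shown below. What is called first, only, known or untested is meant among the compounds shown, and "the series" means these compounds.

Measured so far in an ADME assay on HEK293 cells (Homo sapiens) for cytotoxicity, read by reporter gene assay and resazurin assay, with a stated time of 48 h; a higher number here means that more compound is tolerated, a lower number that less compound is tolerated
- compound 1 `COc1c(Br)cccc1C(=O)Nc1ccc(Sc2nc3ccccc3s2)cc1` gives > 100000 nM as a limit
- compound 2 `O=C(Nc1ccc(Sc2nc3ccccc3s2)c(Cl)c1)c1cccc(Br)c1` gives > 100000 nM as a limit
- compound 3 `O=C(Nc1ccc(Sc2nc3ccccc3s2)c(Cl)c1)c1cc(Br)cc(Br)c1O` gives 76000 nM as a number

Compound 1 and compound 2 stop at the limit of > 100000 nM in this assay, at which 2 of the 3 values shown sit, and so give no number. Only compound 3 gives a true number, which makes it the sole firm reference point in this assay here.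

Compound 4 `COc1c(Br)cccc1C(=O)Nc1ccc(Sc2nc3ccccc3s2)c(Cl)c1` differs from compound 3 in one place, with a group of 9 heavy atoms (7 carbon, 1 oxygen, 1 bromine; one six-membered aromatic ring of carbon only) in place of a group of 9 heavy atoms (6 carbon, 1 oxygen, 2 bromine; one six-membered aromatic ring of carbon only), on a carbonyl carbon as the whole change. Among the measured compounds shown here, the group that enters is the one carried by compound 1.

For the measured compounds named here, one measured step bears on this place, and it is an at least 1.3-fold lower number from compound 2 to compound 3 (0.11 log units; that floor lies within the scatter) as its size. It brought in the same 3,5-dibromo-2-hydroxyphenyl group that now leaves. Since that step shows only a floor within the scatter, no step beyond the scatter is expected in this assay for this exchange.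

The expected change is a 1.3-fold higher number from compound 3 to compound 4 (0.12 log units; within the scatter) and it is estimated to stay within the scatter. For compound 4 the estimated value is 100000 nM with an expected range from 50000 nM to 200000 nM and a limit instead of a number is quite possible.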

Compound 4, half-maximal cytotoxic concentration: > 100000 nM
Compound 4: a limit, no number (the forecaster's own chance of this, stated with the estimate: 65%); the middle value lies on the limit itself.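

At this place on the carbonyl carbon, taking away the 3,5-dibromo-2-hydroxyphenyl group gives an at least 1.3-fold higher number from compound 3 to compound 4 (0.11 log units; that floor lies within the scatter) in this assay. A group with no hydrogen-bond donor can therefore stand here without any change beyond the scatter, and this holds on a core that keeps the chloro group of compound 3. The steps that link compound 4 to compound 1 and to compound 2 cannot be read: the limit of > 100000 nM in this assay, at which 3 of the 4 values shown sit.

Among the compounds shown here, compound 3 remains the only compound with a true number, at 76000 nM, so the size of any change at this place is still unknown. As far as these compounds go, whether a phenyl group carrying an amine or a carboxylic acid at this carbonyl carbon would give a step beyond the scatter in this assay stays open.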